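Removing a methyl from the hydroxyphenyl of compound 2

The source may hold more compounds than are shown below. What is called first, only, known or untested is meant among the compounds shown, and "the series" means these compounds.

Measured compounds:
- compound 1, `O=C(Nc1cccc(-n2cc(-c3ccncc3)c(-c3ccc(Cl)c(O)c3)n2)c1)Nc1cccc(C(F)(F)F)c1`: 3590 nM
- compound 2, `COc1cc(-c2nn(-c3cccc(NC(=O)Nc4ccc(Cl)c(Cl)c4)c3)cc2-c2ccncc2)ccc1Cl`: 698 nM

In a functional assay on MDA-MB-231 cells (Homo sapiens) for inhibition, read by sulforhodamine B assay, with a stated time of 48 h (on this read-out lower numbers stand for stronger inhibition of growth and higher numbers for weaker inhibition of growth), compound 2 gives 698 nM and so has the lower of the two numbers. Compound 1 gives 3590 nM in this assay, a number that stands beyond the usual scatter above that of compound 2. Compound 3, `O=C(Nc1cccc(-n2cc(-c3ccncc3)c(-c3ccc(Cl)c(O)c3)n2)c1)Nc1ccc(Cl)c(Cl)c1`, is not yet measured. It is reached from compound 2 by the change (hydrogen in place of methyl on an oxygen on an aromatic ring), while the rest of the molecule is kept. Compound 1 also carries a hydroxy on that ring, but it differs from compound 3 elsewhere as well, so its value alone cannot fix the size of this step. Among the measured compounds shown here, with no measured pair showing this exact change, a modest step is expected, if any, and its direction is uncertain. Compound 3 is therefore expected to give about 1200 nM in this assay, within 400 nM to 4000 nM, a step of a 1.7-fold higher number from compound 2 to compound 3 (0.24 log units; within the scatter) that is estimated to lie close to the scatter.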

Compound 3, concentration for 50% growth inhibition: 1180 nM
Compound 3: the middle estimate sits 1.0-fold (0.01 log units) above what was measured, within the range that was stated.
By their numbers in this assay, from the lowest: compounds 2 and 3 (each within the scatter of the next); then compound 1.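

In this assay the first pair differing only at this oxygen shows a 1.7-fold higher number from compound 2 to compound 3 (0.23 log units; within the scatter) as methoxy gives way to hydroxy, so on this ring the two groups cannot be told apart beyond the scatter. With the hydroxy kept, 3,4-dichlorophenyl in place of 3-(trifluoromethyl)phenyl on the amide-type nitrogen gives a 3.0-fold lower number from compound 1 to compound 3 (0.48 log units; beyond the scatter) and, unlike the change at the oxygen, this step lies beyond the scatter. Nothing available explains either step.

From the compounds shown here alone, whether a larger group on this oxygen, such as an ethyl or a longer chain, or an amine in place of the hydroxy, would keep the number in the same range remains open. Also open, going by these compounds, is whether the step at the amide-type nitrogen has the same size when methoxy stands on the ring.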